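The compounds below may be only part of what the source reports. "The series", "measured", "known", "first", "only" and "open" are said of these compounds alone.

In an ADME assay on microsomes from liver (Rattus norvegicus) for metabolic stability, read by LC-MS, tested at 0.5 uM (on this read-out higher numbers stand for a longer-lived compound and lower numbers for a shorter-lived compound), compound 1 `Cc1nc(C)c([C@H](OC(C)(C)C)C(=O)O)c(N2CCC(C)(C)CC2)c1-c1ccc(OCCc2ccc(F)c(F)c2)cc1` gives 0.85 h. Compound 2 `Cc1nc(C)c([C@H](OC(C)(C)C)C(=O)O)c(N2CCC(C)(C)CC2)c1-c1ccc(OC2COCC2c2ccc(F)cc2)cc1` reaches only the limit of this assay, > 2 h. Compound 3 `Cc1ccc(CCOc2ccc(-c3c(C)nc(C)c([C@H](OC(C)(C)C)C(=O)O)c3N3CCC(C)(C)CC3)cc2)s1` likewise reaches only the limit, > 2 h, so its standing is known merely as a floor, and the step that the two limits leave unreadable from compound 2 to compound 3 cannot be read. The two steps that can be read both climb: an at least 2.3-fold higher number from compound 1 to compound 2 (0.37 log units; beyond the scatter) and an at least 2.3-fold higher number from compound 1 to compound 3 (0.37 log units; beyond the scatter), each at least modest in size and beyond the scatter. Both end at the limit, as the limit of > 2 h in this assay, at which 2 of the 3 values shown sit, records.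

Compound 4 `Cc1ncsc1CCOc1ccc(-c2c(C)nc(C)c([C@H](OC(C)(C)C)C(=O)O)c2N2CCC(C)(C)CC2)cc1` differs from compound 3 in one place: 4-methyl-1,3-thiazol-5-yl in place of 5-methylthiophen-2-yl on a saturated chain carbon, two bonds along the chain from an oxygen on an aromatic ring. Among the measured compounds shown here, no measured step exchanges one five-membered aromatic ring for another on this chain, so the nearest guidance is that compound 3 sits at the limit. On that basis compound 4 is expected to stay long-lived in this assay, with the estimated step of a number no higher from compound 3 to compound 4 (the limit leaves the size open) judged too uncertain to call in either direction. The estimate for compound 4 is 2 h, within the range 0.8 h to 5 h.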

Compound 4, half-life: > 2 h
Compound 4 was reported as a limit (the forecaster's own chance of this, stated with the estimate: 50%); the middle value lies on the limit itself.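

In this assay compound 4 gives > 2 h, which is a limit and not a number. Set against 3,4-difluorophenyl on this saturated chain carbon, 4-methyl-1,3-thiazol-5-yl brings an at least 2.3-fold higher number from compound 1 to compound 4 (0.37 log units; beyond the scatter), so the climb seen with 5-methylthiophen-2-yl is not confined to that one ring: a five-membered aromatic ring with 2 hetero atoms shows it too. The steps to compound 4 from compound 2 and from compound 3 cannot be read, and the two five-membered rings stay unordered, because all three compounds end at the same limit: the limit of > 2 h in this assay, at which 3 of the 4 values shown sit.

On these data alone, how long compound 2, compound 3 and compound 4 actually last remains open. So does whether a pyridine, a thiazole without its methyl or a longer chain would also reach this limit.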